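The compounds below may be only part of what the source reports. "The series", "measured", "known", "first", "only" and "open" are said of these compounds alone.

Readings so far in a functional assay on BV-2 cells (Mus musculus) for inhibition, read by Griess assay, with a stated time of 24 h (a higher number here means a weaker inhibitor, a lower number a stronger inhibitor), stand as follows
Compound 1 `Oc1ccc(Br)cc1-c1ccn(-c2ccccc2)n1` gives > 200000 nM as a limit, not a number
Compound 2 `C=CCc1ccc(O)c(-c2ccn(-c3ccccc3)n2)c1` gives 73000 nM as a number
Compound 3 `CCCc1ccc(O)c(-c2ccn(-c3ccccc3)n2)c1` gives 109000 nM as a number

Within the data shown here, compound 3 holds one of only two numeric readings. The nearest reading belongs to compound 2, and the gap is a 1.5-fold higher number from compound 2 to compound 3 (0.17 log units; within the scatter) in this comparison. The two other steps are an at least 2.7-fold lower number from compound 1 to compound 2 (0.43 log units; beyond the scatter) and an at least 1.8-fold lower number from compound 1 to compound 3 (0.26 log units; that floor lies within the scatter) for the same place on the core.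

Next comes compound 4 `CCCc1ccc(O)c(-c2cc[nH]n2)c1`, with the change (hydrogen in place of phenyl on an aromatic nitrogen), hydrogen in place of phenyl on an aromatic nitrogen. All three measured steps concern a different place, so none of them sizes this change directly. They give only the level from which it starts, namely compound 3 at 109000 nM in this assay. No step beyond the scatter can be firmly expected, though a slightly higher number seems more likely than a lower one, and the uncertainty is wide. The estimated change is a 1.3-fold higher number from compound 3 to compound 4 (0.11 log units; within the scatter) on this reasoning. For compound 4 the expected value is 140000 nM in this read-out. The estimated range for compound 4 runs from 45000 nM to 350000 nM for a numeric result. Compound 4 could also end at the limit of > 200000 nM in this assay, at which 1 of the 3 values shown sits, which would be a limit and no number.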

Compound 4, half-maximal inhibitory concentration: 60200 nM
Beside the measured number, compound 4's estimate is 2.3-fold (0.37 log units) above it; measured number inside the range.
By their numbers in this assay, from the lowest: compounds 4, 2 and 3 (each within the scatter of the next). At a limit, above all of these: compound 1.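

Among these compounds, the earlier steps all concerned a different place on the core, so this is the only direct reading at the aromatic nitrogen in this assay: a 1.8-fold lower number from compound 3 to compound 4 (0.26 log units; within the scatter). With hydrogen in place of phenyl, a group of 6 heavy atoms leaves this nitrogen with no difference that this read-out can resolve, and compound 4 still gives a number. Compound 1 alone stays at a limit, which is not a number: the limit of > 200000 nM in this assay, at which 1 of the 4 values shown sits.

On these data alone, only hydrogen and phenyl are seen on this nitrogen, and only with propyl elsewhere on the core, so it remains open whether methyl, benzyl or a phenyl carrying a methoxy group would move the reading beyond the scatter. As far as these compounds go, it also remains open whether the allyl and propyl groups would compare in the same way with hydrogen on the nitrogen, and whether an amine or a carboxylic acid at either place would give a reading clearly separate from the numbers in this narrow set.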